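Phenyl for methyl on a saturated ring carbon: series notes

A few compounds are considered here, and "the series" means these few. Any claim that something is new, unique, unknown or untested is made for them only; others in the source may bear on it.

Of the compounds shown here, three on the shared core have been measured. Compound 3 `COc1ccc(C2=NN(C(=O)NS(=O)(=O)c3ccc(C)cc3)CC2C)c(OC)c1` gives 25.1% in a functional assay on the whole organism (strain albino) for inhibition, with Rattus norvegicus as the target, read by paw edema, with stated times of 30 min and 4 h, at a dose of 25 mg/kg by the intraperitoneal route; on this read-out higher numbers stand for more inhibition at the one dose given (going by the name of the read-out) and lower numbers for less inhibition. Compound 1 `COc1ccc(C2=NN(C(=O)NS(=O)(=O)c3ccc(C)cc3)CC2c2ccccc2)c(OC)c1` gives 7.21% in this assay, and the difference between them is phenyl in place of methyl on a saturated ring carbon, which made a step of a number 17.9 percentage points lower from compound 3 to compound 1 (beyond the scatter). Compound 2 `COc1ccc(C2=NN(C(=S)NC(=O)c3ccc(Cl)cc3)CC2C)c(OC)c1` gives 1.43% in this assay; the difference between the core of compound 2 and the core of compound 3 is not broken down here. The number for compound 1 lies within the scatter of that for compound 2, while compound 3 sits beyond the scatter above compound 2.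

Compound 4 `COc1ccc(C2=NN(C(=S)NC(=O)c3ccc(Cl)cc3)CC2c2ccccc2)c(OC)c1` is not yet measured. It differs from compound 2 by phenyl in place of methyl on a saturated ring carbon, the same change as that from compound 3 to compound 1. Because compound 3 to compound 1 gave a number 17.9 percentage points lower from compound 3 to compound 1 (beyond the scatter), and because compound 2 already gives 1.43%, a drop of the earlier size cannot repeat in full; a step of about a number 1.4 percentage points lower from compound 2 to compound 4 (within the scatter) is expected. Compound 4 is estimated at 0%, between -8% and 8%.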

Compound 4, a percentage reported as inhibition, in the whole organism at one dose (the size of the read-out at that dose, not a potency): 1.92%
Estimate against measurement, compound 4: 1.9 percentage points below; the range from low to high includes it.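

On the core of compound 2, phenyl in place of methyl on a saturated ring carbon gives a number 0.5 percentage points higher from compound 2 to compound 4 (within the scatter) in this assay, so the change shows no measurable effect on this core. The change therefore does not carry over at the same size from one core to the other: the same change on two cores in this assay, a number 17.9 percentage points lower (beyond the scatter) from compound 3 to compound 1 and a number 0.5 percentage points higher (within the scatter) from compound 2 to compound 4, 18.4 percentage points apart, beyond the scatter of two such steps These two pairs do not show which part of the cores goes with the gap, and with compound 2 at 1.43% the read-out leaves little room for a fall of the earlier size, so a real difference between the cores cannot be told apart from the low starting value.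

The compounds shown place only methyl and phenyl on this ring carbon, which leaves open how a longer chain such as propyl, or an amine or a carboxylic acid, would read there. Also open, as far as these compounds go, is whether the step seen on the core of compound 3 would recur on another core with a starting value well clear of zero.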